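The compounds below may be only part of what the source reports. "The series", "measured", "known", "first", "only" and "open" are said of these compounds alone.

Measured compounds:
- compound 1, `Cc1ccc(NC(=S)NC(=O)c2ccc(OCc3ccccc3)cc2)cc1-c1nc2ccccc2[nH]1`: 57800 nM
- compound 2, `Cc1ccc(NC(=S)NC(=O)c2ccc(OCc3cccc(Cl)c3)cc2)cc1-c1nc2ccccc2[nH]1`: 43300 nM

In a functional assay on MNK45 cells (Homo sapiens) for inhibition, read by MTT assay, with a stated time of 48 h (on this read-out higher numbers stand for weaker inhibition and lower numbers for stronger inhibition), compound 2 gives the lower of the two numbers shown, yet its distance from compound 1 is a 1.3-fold lower number from compound 1 to compound 2 (0.13 log units; within the scatter), which is within the scatter, so the two compounds cannot be told apart on this read-out. Compound 3, `Cc1ccc(NC(=S)NC(=O)c2ccc(OCc3ccc(C(F)(F)F)cc3)cc2)cc1-c1nc2ccccc2[nH]1`, has not been measured. It differs from compound 2 by 4-(trifluoromethyl)phenyl in place of 3-chlorophenyl on a saturated chain carbon bound to an oxygen on an aromatic ring. Within the data shown here, no measured step touches a trifluoromethyl group; the only step at hand, from compound 1 to compound 2, exchanges hydrogen for chloro on that same benzyl ring and stays within the scatter. With nothing showing that substitution on this ring moves this assay, the expectation for compound 3 is no change beyond the scatter, a step of a 1.1-fold lower number from compound 2 to compound 3 (0.03 log units; within the scatter) from compound 2. Compound 3 is therefore estimated at 40000 nM, within 15000 nM to 110000 nM.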

Compound 3, half-maximal inhibitory concentration: 10200 nM
Compound 3: middle estimate off by 3.9-fold (0.59 log units), on the high side, and the stated range ends above it.
By their numbers in this assay, from the lowest: compound 3; then compounds 2 and 1 (each within the scatter of the next).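

In this assay the phenyl ring on the saturated chain carbon now proves able to move the read-out: 4-(trifluoromethyl)phenyl in place of 3-chlorophenyl gives a 4.2-fold lower number from compound 2 to compound 3 (0.63 log units; beyond the scatter) and this step lies beyond the scatter. The trifluoromethyl exchange taken alone gives a 5.7-fold lower number from compound 1 to compound 3 (0.75 log units; beyond the scatter) and also lies beyond the scatter, so this place responds to what it carries, which the chloro exchange alone had not shown. Nothing at hand explains these steps.

Compound 2 and compound 3 differ in both the group and its place on the ring, so the compounds shown cannot separate the effect of the one from the other. On these data alone, how a methoxy group, a nitrile or an amine on this ring would read also remains open.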